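The source may report more compounds than this note shows. Statements on the series, on what has been measured and on what is new or still open speak of the compounds shown alone.

Among the measured compounds shown here, in a physicochemical assay for solubility, read by HPLC, at pH 6.8 (a higher number here means a more soluble compound, a lower number a less soluble compound), only two compounds have numbers so far. Compound 1 `Cc1cc(-c2nc3cccnn3c2-c2ccnc(NC(=O)c3cccnc3)c2)ccc1F` gives 0.92 ug/mL, and compound 2 `Cc1ccc(C(=O)Nc2cc(-c3c(-c4ccc(F)c(C)c4)nc4cccnn34)ccn2)cn1` gives 0.38 ug/mL, the lower of the two. For the measured compounds named here, the one measured step is a 2.4-fold lower number from compound 1 to compound 2 (0.38 log units; beyond the scatter), where a methyl takes the place of a hydrogen on an aromatic carbon. That step is modest, though beyond the scatter.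

Compound 3 `Cc1cc(C(=O)Nc2cc(-c3c(-c4ccc(F)c(C)c4)nc4cccnn34)ccn2)ccn1` has the same atoms as compound 2, joined differently: 2-methylpyridin-4-yl in place of 6-methylpyridin-3-yl on a carbonyl carbon. Put simply, 2-methylpyridin-4-yl stands in place of 6-methylpyridin-3-yl on a carbonyl carbon.

Going by the values given here, no measured step shows a swap of this kind, so the data give no direction for it. Among the compounds with values here, the only guide to size is a 2.4-fold lower number from compound 1 to compound 2 (0.38 log units; beyond the scatter), a different change of modest size. A shift no larger than that is therefore expected, and most likely none beyond the scatter. The expected change is a 1.3-fold higher number from compound 2 to compound 3 (0.12 log units; within the scatter), a small estimate with little evidence behind it. In this assay, the estimate for compound 3 is 0.5 ug/mL, with an expected range from 0.15 ug/mL to 1.5 ug/mL.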

Compound 3, solubility: 0.15 ug/mL
Compound 3: middle estimate off by 3.3-fold (0.52 log units), on the high side; the range from low to high includes it.
By their numbers in this assay, from the lowest: compound 3; then compound 2; then compound 1.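

Putting 2-methylpyridin-4-yl in place of 6-methylpyridin-3-yl on the carbonyl carbon leaves the counts of heavy atoms, hydrogen-bond donors and acceptors unchanged, yet it gives a 2.5-fold lower number from compound 2 to compound 3 (0.40 log units; beyond the scatter) in this assay and so shows that the way the same atoms are joined at this position can matter, not only which atoms are present. Set against the plain pyridin-3-yl group, 2-methylpyridin-4-yl gives a 6.1-fold lower number from compound 1 to compound 3 (0.79 log units; beyond the scatter) and this is the largest step among the three compounds, leaving both compounds that carry a methyl on this ring with lower numbers than compound 1. No measurement available here explains why rejoining the same atoms shifts the number.

All the steps shown run downward, so it remains open whether any group on this carbonyl carbon can lift the number above that of compound 1. Plain pyridin-4-yl would help separate the methyl from the change of ring attachment, and an amine or a carboxylic acid in place of the methyl would test a quite different kind of group.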